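Compound 4 in the cytotoxicity series: step from compound 3

The compounds below may be only part of what the source reports. "The series", "measured", "known", "first", "only" and "open" are said of these compounds alone.

Measured so far in a functional assay on OVCAR-8 cells (Homo sapiens) for cytotoxicity, read by sulforhodamine B assay, with a stated time of 48 h, tested at 100 uM; a higher number here means a weaker effect of the compound at the concentration tested, a lower number a stronger effect:
compound 1 `COc1cc(-c2cc(/C=C/C(=O)c3ccc(N)cc3)[nH]n2)cc(OC)c1OC`, -91%;
compound 2 `COc1ccc(C(=O)/C=C/c2cc(-c3cc(OC)c(OC)c(OC)c3)n[nH]2)cc1OC`, -96%;
compound 3 `COc1ccc(C(=O)/C=C/c2cc(-c3cc(OC)c(OC)c(OC)c3)n[nH]2)cc1`, -16%.

Compound 3 stands highest of the three, weakest at the concentration tested, above compound 1 by a number 75 percentage points higher from compound 1 to compound 3 (beyond the scatter) and above compound 2 by a number 80 percentage points higher from compound 2 to compound 3 (beyond the scatter). Compound 4 `COc1cc(-c2cc(/C=C/C(=O)c3ccc(F)c(F)c3)[nH]n2)cc(OC)c1OC` differs from compound 3 by 3,4-difluorophenyl in place of 4-methoxyphenyl on a carbonyl carbon. All three measured steps change this same ring: a number 5 percentage points lower from compound 1 to compound 2 (within the scatter) was small, whereas a number 75 percentage points higher from compound 1 to compound 3 (beyond the scatter) and a number 80 percentage points higher from compound 2 to compound 3 (beyond the scatter) were large, so changes on this ring can move this assay strongly in either direction. Going by the values given here, no measured pair shows fluorine entering. Compound 4 is expected to stay near compound 3, with a step of a number 9 percentage points lower from compound 3 to compound 4 (within the scatter), and its estimated value is -25%, in the range -70% to 5%.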

Compound 4, a percentage reported as activity, at one concentration (the size of the read-out at that concentration, not a potency): -12%
Estimate against measurement, compound 4: 13 percentage points below, within the range that was stated.
By their numbers in this assay, from the lowest: compounds 2 and 1 (each within the scatter of the next); then compounds 3 and 4 (each within the scatter of the next).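

In this assay, 3,4-difluorophenyl on the carbonyl carbon does not separate from 4-methoxyphenyl (a number 4 percentage points higher from compound 3 to compound 4 (within the scatter)), yet it stands far from 3,4-dimethoxyphenyl (a number 84 percentage points higher from compound 2 to compound 4 (beyond the scatter)) and from 4-aminophenyl (a number 79 percentage points higher from compound 1 to compound 4 (beyond the scatter)). The weak result at this position therefore no longer rests on compound 3 alone, and a second group now shares it. Nothing available explains this split.

Still open, from the compounds shown here alone, is whether a 4-hydroxyphenyl or 4-carboxyphenyl group at this place would fall with compound 1 and compound 2 or with compound 3 and compound 4.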